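Swapping a Thiophen-2-yl for a Phenyl on a Shared Core

The source may hold more compounds than are shown below. What is called first, only, known or untested is meant among the compounds shown, and "the series" means these compounds.

Measured compounds:
compound 1, `N=C(S)CCn1nc(-c2cccs2)ccc1=O`: 100 mg/kg
compound 2, `N=C(S)CCn1ncccc1=S`: 100 mg/kg
compound 3, `N=C(S)CCn1nc(-c2ccc(Cl)c(Cl)c2)ccc1=O`: 78.1 mg/kg

These three compounds were tested in a functional assay on the whole organism (stomach) with Rattus norvegicus as the target; on this read-out higher numbers stand for an effect only at larger amounts of compound and lower numbers for an effect already at smaller amounts. In this assay compound 1 gives 100 mg/kg, compound 2 gives 100 mg/kg and compound 3 gives 78.1 mg/kg. Compound 1 and compound 2 sit level at the digits shown, and together they carry the highest numbers of the three. Compound 3 has the lowest number, yet its distance from compound 1 stays within the usual scatter, so the three values cannot be told apart with confidence.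

The next compound, compound 4, `N=C(S)CCn1nc(-c2ccccc2)ccc1=O`, has not yet been measured. Against compound 1 its single change is this: phenyl in place of thiophen-2-yl on an aromatic carbon. Among the measured compounds shown here, no pair of measured compounds shows this change, so its size in this assay is unknown. For the measured compounds named here, the three values so far lie close together, and the change is modest, so no step beyond the scatter is expected here.

Compound 4 is therefore expected to give about 100 mg/kg, in a range from 50 mg/kg to 200 mg/kg. That estimate means a step of no change at the digits printed from compound 1 to compound 4 (within the scatter), expected to stay within the scatter.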

Compound 4, dose for half-maximal effect: 87.3 mg/kg
Compound 4: middle estimate off by 1.1-fold (0.06 log units), on the high side; the range from low to high includes it.
By their numbers in this assay, from the lowest: compounds 3, 4, 1 and 2 (each within the scatter of the next).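

Exchanging thiophen-2-yl for phenyl on this aromatic carbon gives, in this assay, a 1.1-fold lower number from compound 1 to compound 4 (0.06 log units; within the scatter), so the two compounds cannot be told apart. Among the compounds shown here, this is the first pair in the set that differs in only one place, and it gives the first direct reading at this position: a five-membered aromatic ring holding a sulfur atom and a six-membered aromatic ring of carbon only are interchangeable here, as far as this read-out can show, even though the swap also changes the heavy-atom count and removes the hydrogen-bond acceptor counted for thiophen-2-yl. Nothing measured on these compounds offers an explanation for this result, and a flat step between two aromatic rings on its own gives no account of how the position works.

Both groups at this position are uncharged aromatic rings, so the step says nothing about how a very different group would behave there, such as an amine, a carboxylic acid or a simple methyl. As far as these compounds go, it also remains open whether any change at this carbon, or a longer chain in place of the side chain on the ring nitrogen, can move the number beyond the scatter in this assay.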